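A few compounds are considered here, and "the series" means these few. Any claim that something is new, unique, unknown or untested is made for them only; others in the source may bear on it.

Compound 1 `CO/N=C(/CCN1CCN(c2ccccn2)CC1)c1ccc(Cl)cc1` and compound 2 `CO/N=C(\c1ccc(Cl)cc1)C(O)CN1CCN(c2ccccn2)CC1` share a core and differ in one place. In a functional assay on HEK293 cells with D(4) dopamine receptor (Homo sapiens) as the target, read by FLIPR (on this read-out lower numbers stand for smaller maximal responses and higher numbers for larger maximal responses), compound 1 gives 68%, while compound 2 gives 89%, the higher of the two numbers. The step of a number 21 percentage points higher from compound 1 to compound 2 (beyond the scatter) introduces a hydroxy in place of hydrogen on a saturated chain carbon bound to a carbon with a double bond to nitrogen and a saturated chain carbon.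

Compound 3 `CO/N=C(\c1ccc(Cl)cc1)C(CN1CCN(c2ccccn2)CC1)OC` takes this further: methyl in place of hydrogen on an oxygen on a saturated carbon. No measured step changes a hydroxy to a methoxy, so the only guide is the size of the one step shown, which was modest. The hydroxy of compound 2 remains as an oxygen in compound 3, but its hydrogen is replaced, and the data give no direct reading of that exchange. Compound 3 is therefore expected to land somewhat below compound 2, an estimated step of a number 11 percentage points lower from compound 2 to compound 3 (beyond the scatter) in this assay, with a good chance that the change stays within the scatter. The estimate for compound 3 in this assay is 78%, with a range from 60% to 95%.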

Compound 3, largest response reached (reported as efficacy), in percent of the reference or control that the assay uses: 79%
Estimate against measurement, compound 3: 1 percentage points below; the range from low to high includes it.
By their numbers in this assay, from the lowest: compound 1; then compounds 3 and 2 (each within the scatter of the next).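

In this assay, the change of hydroxy to methoxy on this saturated carbon gives a number 10 percentage points lower from compound 2 to compound 3 (within the scatter), so at this position the hydrogen of the hydroxy can be exchanged for a methyl without a change that stands out from the usual variation between repeats. The comparison with the unsubstituted chain points the same way: methoxy in place of hydrogen on that saturated chain carbon gives a number 11 percentage points higher from compound 1 to compound 3 (beyond the scatter), so the rise in maximal response seen with the hydroxy does not depend on keeping a hydrogen on the oxygen, and in these three compounds both oxygen-bearing groups stand clear of compound 1. Why an oxygen at this carbon goes with a larger maximal response cannot be told from these numbers, as nothing else measured bears on it.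

The compounds shown leave open whether the oxygen itself matters, since an amine, a fluorine or a plain methyl on the same carbon would separate the effect of the oxygen from that of having any group there at all. They also leave open how much room the position allows beyond methyl on the oxygen, which an ethoxy or a benzyloxy group would test.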